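Notes on the step from compound 2 to compound 4

This account rests on a few compounds, and the source may have more. Where it says the series, first, only, none or still open, it means among the compounds named here.

In an ADME assay on A549 cells (Homo sapiens) for cytotoxicity, read by resazurin assay, with a stated time of 48 h (a higher number here means that more compound is tolerated, a lower number that less compound is tolerated), compound 1 `CC(C)Nc1ccc(NC(=O)c2cc(Cl)ccc2O)c(Cl)c1` gives 11000 nM as its value, compound 2 `CC(C)CNc1ccc(NC(=O)c2cc(Cl)ccc2O)c(Cl)c1` gives 60000 nM as its value, and compound 3 `CC1(Nc2ccc(NC(=O)c3cc(Cl)ccc3O)c(Cl)c2)CCCC1` gives 157000 nM as the highest number. Compound 2 therefore stands second highest of the three.

Compound 4 `O=C(Nc1ccc(NCc2ccc(C(F)(F)F)cc2)cc1Cl)c1cc(Cl)ccc1O` differs from compound 2 by 4-(trifluoromethyl)phenyl in place of isopropyl on a saturated chain carbon bound to a nitrogen on an aromatic ring.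

The nearest measured changes are a 5.5-fold higher number from compound 1 to compound 2 (0.74 log units; beyond the scatter) (modest), a 2.6-fold higher number from compound 2 to compound 3 (0.42 log units; beyond the scatter) (modest) and a 14-fold higher number from compound 1 to compound 3 (1.15 log units; beyond the scatter) (large). Within the data shown here, the numbers rise in the order isopropyl, isobutyl, 1-methylcyclopentyl, with no compound against that order, but none of these three groups contains an aromatic ring. These steps therefore give a guide to size and only a weak guide to direction for compound 4.

A modest step to a lower number is expected in this assay as a judgement on the entering ring, and the uncertainty is wide in both directions. The estimated step is a 2.4-fold lower number from compound 2 to compound 4 (0.38 log units; beyond the scatter) in this assay. For compound 4 the expected value is 25000 nM with an estimated range of 6000 nM to 90000 nM in this assay.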

Compound 4, half-maximal cytotoxic concentration: 62700 nM
Compound 4: the middle estimate sits 2.5-fold (0.40 log units) below what was measured; the range from low to high includes it.
By their numbers in this assay, from the lowest: compound 1; then compounds 2 and 4 (each within the scatter of the next); then compound 3.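

In this assay, 4-(trifluoromethyl)phenyl in place of isopropyl gives a 1.0-fold higher number from compound 2 to compound 4 (0.02 log units; within the scatter), so this place on a saturated chain carbon bound to a nitrogen on an aromatic ring accepts one six-membered aromatic ring of carbon only with no step beyond the scatter. The earlier compounds shown here carried no aromatic ring in this group, and each of their changes, such as a 5.5-fold higher number from compound 1 to compound 2 (0.74 log units; beyond the scatter) and a 2.6-fold higher number from compound 2 to compound 3 (0.42 log units; beyond the scatter), lay beyond the scatter; this pair shows that a change from 3 to 10 heavy atoms in the leaving and entering groups need not shift the number at all. No measurement offered here bears on the reason for this result.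

The compounds shown do not separate the contribution of the aromatic ring from that of the trifluoromethyl group, a question that a plain phenyl at the same place would address. On these data alone, it also remains open whether an amine, a carboxylic acid or a longer chain carried at this place would keep the number level with those of compound 2 and compound 4.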